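Solubility of the core: aminopiperidine to sulfonylpiperazine

This account rests on a few compounds, and the source may have more. Where it says the series, first, only, none or still open, it means among the compounds named here.

Among the measured compounds shown here, the three measured members share one core and differ only in the ring attached to the aromatic carbon. Compound 1 `COc1cc2nnc(C(N)=O)c(Nc3ccc(C)cc3F)c2cc1N1CCN(C(C)C)CC1` gives 40000 nM in a physicochemical assay for solubility; on this read-out higher numbers stand for higher solubility and lower numbers for lower solubility; compound 2 `COc1cc2nnc(C(N)=O)c(Nc3ccc(C)cc3F)c2cc1N1C[C@@H](C)N[C@@H](C)C1` gives 200000 nM in this assay; compound 3 `COc1cc2nnc(C(N)=O)c(Nc3ccc(C)cc3F)c2cc1N1CCC(OC)CC1` gives 2000 nM in this assay. Compound 3 stands lowest of the three: the step of a 20-fold lower number from compound 1 to compound 3 (1.30 log units; beyond the scatter) and the step of a 100-fold lower number from compound 2 to compound 3 (2.00 log units; beyond the scatter) both point downward to it, and both lie beyond the scatter.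

Compound 4 `COc1cc2nnc(C(N)=O)c(Nc3ccc(C)cc3F)c2cc1N1CCN(S(C)(=O)=O)CC1` is obtained from compound 3 by the change (4-(methylsulfonyl)piperazin-1-yl in place of 4-methoxypiperidin-1-yl on an aromatic carbon). The two steps that reach compound 3 both exchange a piperazine for the methoxypiperidine, and the new compound reverses that exchange, so they bear on it. Yet both measured piperazines carry either an isopropyl group or two methyl groups and an unsubstituted second nitrogen, whereas compound 4 carries a methylsulfonyl on that nitrogen. Neither step can therefore be transferred in full. A modest rise beyond the scatter is expected rather than a return to the numbers of compound 1 or compound 2, and the step of a 2.5-fold higher number from compound 3 to compound 4 (0.40 log units; beyond the scatter) is the estimated outcome. For compound 4 the estimate in this assay is 5000 nM, within a range from 1000 nM to 25000 nM.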

Compound 4, solubility: < 1000 nM
Compound 4 ended at the assay's limit; the forecaster's own chance of this, stated with the estimate: 5%; middle value at least 5.0-fold (0.69 log units) away from the limit.
By their numbers in this assay, from the lowest: compound 3; then compound 1; then compound 2. At a limit, below all of these: compound 4.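

In this assay compound 4 stands at a limit and not at a number, so every step to it gives only a floor: the limit of < 1000 nM in this assay, at which 1 of the 4 values shown sits. With the piperazine kept and only the group on its ring nitrogen exchanged, the result is an at least 40-fold lower number from compound 1 to compound 4 (1.60 log units; beyond the scatter), and the comparison with the dimethylated piperazine is an at least 200-fold lower number from compound 2 to compound 4 (2.30 log units; beyond the scatter), so a piperazine at this aromatic carbon does not by itself keep the number high in this set. Against the methoxypiperidine the result is an at least 2.0-fold lower number from compound 3 to compound 4 (0.30 log units; that floor lies within the scatter), and how large this step really is stays unread, so the two non-amine-bearing ends of the series cannot be separated with confidence.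

An acetyl group or a plain methyl on the same ring nitrogen would show whether the fall belongs to the methylsulfonyl group alone or to any replacement of the isopropyl group. On these data alone, how far compound 4 lies under its limit also stays open, and with it the true size of all three steps.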